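Sulfur linkage change on the methoxyphenyl arm of compound 3

The compounds below may be only part of what the source reports. "The series", "measured", "known", "first", "only" and "open" are said of these compounds alone.

For the measured compounds named here, compound 3 `COc1ccc(CCCCCCCCOc2ccc(CSc3cccc(OC)c3)nc2/C=C/C(=O)O)cc1` stands at the highest number among the three compounds measured so far in an assay for binding affinity to leukotriene B4 receptor 1 (Homo sapiens) (a higher number here means a weaker inhibitor, a lower number a stronger inhibitor), where compound 3 gives 192 nM. Its nearest neighbour is compound 1 `COc1ccc(CCCCCCCCOc2ccc(C[S+]([O-])c3cccc(C(=O)O)c3)nc2/C=C/C(=O)O)cc1`, for which compound 1 gives 151 nM, the gap being a 1.3-fold higher number from compound 1 to compound 3 (0.10 log units; within the scatter). Far off is compound 2 `COc1ccc(CCCCCCCCOc2ccc(C[S+]([O-])c3cccc(N)c3)nc2/C=C/C(=O)O)cc1`; compound 2 gives 4.7 nM, and the gap is a 41-fold higher number from compound 2 to compound 3 (1.61 log units; beyond the scatter).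

Compound 4 `COc1ccc(CCCCCCCCOc2ccc(C[S+]([O-])c3cccc(OC)c3)nc2/C=C/C(=O)O)cc1` differs from compound 3 by a group of 10 heavy atoms (7 carbon, 2 oxygen, 1 sulfur; one six-membered aromatic ring of carbon only) in place of a group of 9 heavy atoms (7 carbon, 1 oxygen, 1 sulfur; one six-membered aromatic ring of carbon only), on a saturated chain carbon bound to an aromatic carbon. Going by the values given here, no measured pair isolates this change. The step from compound 1 to compound 3 combines it with the exchange of carboxy for methoxy on the ring and came out as a 1.3-fold higher number from compound 1 to compound 3 (0.10 log units; within the scatter), within the scatter. The large step of a 32-fold lower number from compound 1 to compound 2 (1.51 log units; beyond the scatter) concerns the ring substituent, not the linkage, and so does not bear directly on compound 4. Compound 1 and compound 2 already carry the entering kind of linkage, and compound 1, with its carboxy ring, sits close to compound 3.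

The expectation for compound 4 in this assay is therefore a change of a 1.2-fold lower number from compound 3 to compound 4 (0.08 log units; within the scatter), not beyond the scatter. Compound 4 is estimated at 160 nM, with a range from 50 nM to 500 nM.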

Compound 4, inhibition constant: 232 nM
Beside the measured number, compound 4's estimate is 1.5-fold (0.16 log units) below it; low and high end bracket the measured number.
By their numbers in this assay, from the lowest: compound 2; then compounds 1, 3 and 4 (each within the scatter of the next).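

In this assay, for the compounds shown here, a 1.2-fold higher number from compound 3 to compound 4 (0.08 log units; within the scatter) gives the first isolated reading of the linkage change: with the 3-methoxyphenyl ring held constant, the extra oxygen in the group on the saturated chain carbon leaves the number within the scatter. With the linkage also held constant, the ring substituent can now be read alone: a 49-fold higher number from compound 2 to compound 4 (1.69 log units; beyond the scatter) is large, whereas a 1.5-fold higher number from compound 1 to compound 4 (0.19 log units; within the scatter) is not, so among the amino, carboxy and methoxy compounds sharing this linkage, only amino stands apart, and methoxy and carboxy do not separate. No supporting data bear on why the linkage change leaves the number within the scatter or why amino stands apart.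

Going by these compounds, the linkage change has been read only with the methoxy ring, so it remains open whether an amino ring joined through the sulfanyl linkage would keep a number close to that of compound 2. Also open, on these data alone, are whether a sulfone, with a further oxygen on the sulfur, would stay within the scatter of compound 4, and whether a methylamino or acetamido group on the aromatic carbon would follow amino or methoxy.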